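Imidazolylethyl in place of piperidinylpropyl on the azaindazole nitrogen

A few compounds are considered here, and "the series" means these few. Any claim that something is new, unique, unknown or untested is made for them only; others in the source may bear on it.

Compound 1, `Cn1cc(C2=C(c3nn(CCCn4cncn4)c4ncccc34)C(=O)NC2=O)c2ccccc21`: > 100000 nM
Compound 2, `Cn1cc(C2=C(c3nn(CCCn4cncn4)c4ncccc34)C(=O)N(c3ccccc3)C2=O)c2ccccc21`: > 100000 nM
Compound 3, `Cn1cc(C2=C(c3nn(CCCN4CCCCC4)c4ncccc34)C(=O)N(c3ccccc3)C2=O)c2ccccc21`: 20600 nM

Three compounds sharing one core were tested in a functional assay on A549 cells (Homo sapiens) for antiproliferative activity, read by MTT assay, with a stated time of 48 h; on this read-out higher numbers stand for weaker inhibition and lower numbers for stronger inhibition. Compound 1 reached only a limit of the assay, > 100000 nM, not a number. Compound 2 likewise sits at the limit, > 100000 nM. The step that the two limits leave unreadable from compound 1 to compound 2 therefore cannot be read. Among the compounds with values here, compound 3 is the only one of the three with a number, 20600 nM, and the step of an at least 4.8-fold lower number from compound 2 to compound 3 (0.68 log units; beyond the scatter) is the one readable change in this set. The evidence the limit of > 100000 nM in this assay, at which 2 of the 3 values shown sit, shows how much of the set lies at that limit.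

Compound 4, `Cn1cc(C2=C(c3nn(CCn4ccnc4)c4ncccc34)C(=O)N(c3ccccc3)C2=O)c2ccccc21`, is not yet measured. It differs from compound 3 by 1H-imidazol-1-yl in place of (piperidin-1-yl)methyl on a saturated chain carbon, two bonds along the chain from an aromatic nitrogen. Within the data shown here, the one step that bears on it is an at least 4.8-fold lower number from compound 2 to compound 3 (0.68 log units; beyond the scatter), where a five-membered aromatic azole gave way to piperidin-1-yl and the number fell. Compound 4 brings back a five-membered aromatic ring with two hetero atoms, and the chain is one carbon shorter. A move back toward a higher number is expected, with a 2.9-fold higher number from compound 3 to compound 4 (0.46 log units; beyond the scatter) for compound 4. The estimate for compound 4 in this assay is 60000 nM, between 20000 nM and 150000 nM, with a real chance that only a limit is reported.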

Compound 4, half-maximal inhibitory concentration: 43100 nM
Estimate against measurement, compound 4: 1.4-fold (0.14 log units) above; the range from low to high includes it.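

In this assay, an aromatic azole at the chain end no longer rules out a measured number: compound 4, with its 2-(1H-imidazol-1-yl)ethyl group, gives one, whereas compound 2 stays at a limit. Piperidin-1-yl is therefore not required for a measured number among these compounds, although replacing 3-(piperidin-1-yl)propyl still gives a 2.1-fold higher number from compound 3 to compound 4 (0.32 log units; beyond the scatter). Against the triazole-bearing chain, the change gives an at least 2.3-fold lower number from compound 2 to compound 4 (0.36 log units; beyond the scatter), which is a bound and not an exact size: the limit of > 100000 nM in this assay, at which 2 of the 4 values shown sit.

Both steps change the ring and the chain length together, so the compounds shown cannot separate the two effects. A 3-(1H-imidazol-1-yl)propyl or 2-(piperidin-1-yl)ethyl group would divide them, and a morpholin-4-yl group would test another saturated ring at the chain end.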